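Compound 4: swapping dimethylamino for piperidin-1-yl

The compounds below may be only part of what the source reports. "The series", "measured", "known", "first", "only" and "open" are said of these compounds alone.

Among the compounds with values here, in a functional assay on T47D cells (Homo sapiens) for cytotoxicity, read by MTT assay, with a stated time of 2 days (on this read-out lower numbers stand for stronger inhibition and higher numbers for weaker inhibition), compound 1 (`Cc1ccc2nc(-c3ccccc3N(C)C)[nH]c(=O)c2c1`) gives 26700 nM, the only true number so far. Compound 2 (`CN(C)c1ccc2nc(-c3cccc4ccccc34)[nH]c(=O)c2c1`) gives > 50000 nM, which is a limit of the assay and not a number. Compound 3 (`Cc1ccc2nc(-c3ccccc3C)[nH]c(=O)c2c1`) gives > 50000 nM, also a limit. The series thus stands largely at the limit of > 50000 nM in this assay, at which 2 of the 3 values shown sit, and compound 2 sits there with no measured potency.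

Compound 4 (`O=c1[nH]c(-c2cccc3ccccc23)nc2ccc(N3CCCCC3)cc12`) carries piperidin-1-yl in place of dimethylamino on an aromatic carbon.

Within the data shown here, the one measured step is an at least 1.8-fold higher number from compound 1 to compound 3 (0.27 log units; that floor lies within the scatter). It is a different exchange, methyl in place of dimethylamino, and it gives only a floor, so it offers little guidance on the size of this change. Among the measured compounds shown here, no measured step supports a shift in this assay beyond the scatter. The expected change is a number no higher from compound 2 to compound 4 (the limit leaves the size open), and another limit is the likeliest report. For compound 4 the estimated value is 50000 nM, with an expected range of 18000 nM to 90000 nM.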

Compound 4, half-maximal inhibitory concentration: > 50000 nM
Compound 4: a limit, no number (the forecaster's own chance of this, stated with the estimate: 65%); the middle value sits exactly at the limit.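

Compound 2 and compound 4 both stand at a limit, not a number, in this assay, so the exchange of dimethylamino for piperidin-1-yl gives no readable step: the limit of > 50000 nM in this assay, at which 3 of the 4 values shown sit. The compounds shown leave open whether this exchange changes potency at all, and in which direction.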